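From dimethylamino to diethylamino on a fluoro compound

The source may report more compounds than this note shows. Statements on the series, on what has been measured and on what is new or still open speak of the compounds shown alone.

Measured in a functional assay on A549 cells (Homo sapiens) for cytotoxicity, read by MTT assay, with a stated time of 72 h; on this read-out higher numbers stand for weaker inhibition and lower numbers for stronger inhibition:
- compound 1 `CN(C)Cc1ccc2nc(NC(=O)N/N=C3\C(=O)Nc4ccc(Cl)cc43)sc2c1`: 3180 nM
- compound 2 `CN(C)Cc1ccc2nc(NC(=O)N/N=C3\C(=O)Nc4ccc(F)cc43)sc2c1`: 2310 nM
- compound 3 `CCN(CC)Cc1ccc2nc(NC(=O)N/N=C/c3cn(Cc4ccc(C)cc4)c4ccccc34)sc2c1`: 1510 nM

In this assay, compound 2 gives 2310 nM, which lies within the scatter of both compound 1 and compound 3. Compound 4 `CCN(CC)Cc1ccc2nc(NC(=O)N/N=C3\C(=O)Nc4ccc(F)cc43)sc2c1` has not yet been measured. It differs from compound 2 by one change, diethylamino in place of dimethylamino on a saturated chain carbon bound to an aromatic carbon.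

Among the measured compounds shown here, the only measured step is a 1.4-fold lower number from compound 1 to compound 2 (0.14 log units; within the scatter). It lies within the scatter, but it exchanges a halogen and says nothing directly about this change. For the measured compounds named here, no measured pair isolates the new group. Compound 3 also carries diethylamino and gives 1510 nM, but the rest of its structure is different. Going by the values given here, that value is still close to the one for compound 2, so no step beyond the scatter is expected. The estimated step is a 1.2-fold lower number from compound 2 to compound 4 (0.06 log units; within the scatter). For compound 4 the expected value is 2000 nM, with an estimated range from 1050 nM to 3800 nM.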

Compound 4, half-maximal inhibitory concentration: 2010 nM
The estimate for compound 4 lay 1.0-fold (0.00 log units) below the measured number; the range from low to high includes it.
By their numbers in this assay, from the lowest: compounds 3, 4, 2 and 1 (each within the scatter of the next, the first and the last beyond it).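

In this assay, the exchange of dimethylamino for diethylamino on a saturated chain carbon bound to an aromatic carbon now has a matched pair, with a 1.1-fold lower number from compound 2 to compound 4 (0.06 log units; within the scatter) on the fluoro compound. Before this, the only matched pair concerned the halogen, and compound 3 differed from the others in more than this group; the new pair shows that going from 3 to 5 heavy atoms at this place, with no ring or charge introduced, leaves the number within the scatter. No measurement is available that would explain this outcome.

On these data alone, whether the same exchange holds on the chloro compound remains open. Also open, as far as these compounds go, is how a cyclic amine such as pyrrolidine or morpholine, or a primary amine, would read out at this place.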